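From furan-2-yl to a larger aromatic group

A few compounds are considered here, and "the series" means these few. Any claim that something is new, unique, unknown or untested is made for them only; others in the source may bear on it.

Among the measured compounds shown here, only two compounds have been measured so far in an ADME assay on J774.A1 cells (Mus musculus) for cytotoxicity, read by MTT assay, with a stated time of 72 h; on this read-out higher numbers stand for lower toxicity in this test and lower numbers for higher toxicity in this test. Compound 1 `N/C(=N/O)c1ccc(C2=C(S(=O)(=O)c3ccc(F)cc3)CC(c3ccccc3)(c3ccccc3)O2)cc1` gives 10200 nM. Compound 2 `CC1(c2ccc(-c3ccco3)cc2)CC(S(=O)(=O)c2ccc(F)cc2)=C(c2ccc(/C(N)=N\O)cc2)O1` gives 4560 nM, the lower of the two numbers and a gap beyond the usual scatter. For the measured compounds named here, no single-change step between measured compounds is available as a guide. Compound 3 `CC1(c2ccc(-c3cccc(/C(N)=N\O)c3)cc2)CC(S(=O)(=O)c2ccc(F)cc2)=C(c2ccc(/C(N)=N\O)cc2)O1` departs from compound 2 at one place, on an aromatic carbon para to a large group: a group of 10 heavy atoms (7 carbon, 2 nitrogen, 1 oxygen; one six-membered aromatic ring of carbon only) in place of a group of 5 heavy atoms (4 carbon, 1 oxygen; one five-membered aromatic ring with 1 hetero atom), on an aromatic carbon. Furan-2-yl leaves, and a group with a six-membered aromatic ring of carbon only enters. The estimated step of a 1.5-fold higher number from compound 2 to compound 3 (0.19 log units; within the scatter) is modest and points towards a higher number in this assay, though it may stay within the scatter. That expectation rests only on compound 1, which at 10200 nM stands above compound 2. For compound 3 the expected value is 7000 nM, within an estimated range of 2500 nM to 20000 nM.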

Compound 3, half-maximal cytotoxic concentration: 11000 nM
Estimate against measurement, compound 3: 1.6-fold (0.20 log units) below, and the stated range covers the measured number.
By their numbers in this assay, from the lowest: compound 2; then compounds 1 and 3 (each within the scatter of the next).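

Among the compounds shown here, at this place, on an aromatic carbon para to a large group, replacing furan-2-yl with the larger group built on a six-membered aromatic ring of carbon only gives the first single-change reading in this assay, a move of a 2.4-fold higher number from compound 2 to compound 3 (0.38 log units; beyond the scatter). The position therefore responds to the change, and the larger group, with its 2 hydrogen-bond donors, goes with lower toxicity in this test rather than higher. No measurement shown explains why the number moves.

The compounds shown do not separate the contribution of the six-membered ring from that of the nitrogen-bearing part of the entering group, so a plain phenyl at this place remains an open comparison. On these data alone, how a carboxylic acid or an amine on that ring would read is also open.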